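The compounds below may be only part of what the source reports. "The series", "measured", "known", "first", "only" and "open" are said of these compounds alone.

Working notes on the series in a functional assay on SF-539 cells (Homo sapiens) for inhibition; on this read-out higher numbers stand for weaker inhibition of growth and lower numbers for stronger inhibition of growth.

Of the compounds shown here, three have been measured. Compound 1 `COc1cc(/C=C/C(=O)c2cccc(-n3cc(-c4ccc(Cl)cc4)[nH]c3=O)c2)cc(OC)c1OC` gives 3490 nM. Compound 2 `COc1cc(/C=C/C(=O)c2cccc(-n3cc(-c4ccccc4)[nH]c3=O)c2)cc(OC)c1OC` gives 1680 nM. Compound 3 `COc1ccc(-c2cn(-c3cccc(C(=O)/C=C/c4cc(OC)c(OC)c(OC)c4)c3)c(=O)[nH]2)cc1` gives 2000 nM, which places compound 3 as the second highest of the three numbers; its nearest neighbour is compound 2 and its furthest is compound 1, and both gaps lie within the scatter, so no order among compounds 2 and 3 can be read from them.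

Compound 4 `COc1cc(/C=C/C(=O)c2cccc(-n3cc(-c4cc(OC)c(OC)c(OC)c4)[nH]c3=O)c2)cc(OC)c1OC` has not been measured. It differs from compound 3 by 3,4,5-trimethoxyphenyl in place of 4-methoxyphenyl on an aromatic carbon. Going by the values given here, the one measured step that touches the same ring is a 1.2-fold higher number from compound 2 to compound 3 (0.08 log units; within the scatter), which falls within the scatter; the step of a 1.7-fold lower number from compound 1 to compound 3 (0.24 log units; within the scatter) also falls within the scatter, and only a 2.1-fold lower number from compound 1 to compound 2 (0.32 log units; beyond the scatter) passed beyond it, in a modest way. Among the compounds with values here, no measured pair shows a pair of methoxy groups added on this ring, so the data give no direct precedent for the size of the change into compound 4.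

On that basis the expected step is small in this assay, with no clear direction: compound 4 is estimated at 2300 nM with a range from 900 nM to 6000 nM, a step of a 1.2-fold higher number from compound 3 to compound 4 (0.06 log units; within the scatter) that is expected to stay near the scatter.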

Compound 4, concentration for 50% growth inhibition: 3120 nM
For compound 4 the middle estimate is 1.4-fold (0.13 log units) below the measured one; low and high end bracket the measured number.
By their numbers in this assay, from the lowest: compounds 2, 3, 4 and 1 (each within the scatter of the next, the first and the last beyond it).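

In this assay, the position on the aromatic carbon of the five-membered aromatic ring now carries a much larger group, with 3,4,5-trimethoxyphenyl (12 heavy atoms) in place of 4-methoxyphenyl (8 heavy atoms), and this gives a 1.6-fold higher number from compound 3 to compound 4 (0.19 log units; within the scatter). Going by these compounds alone, the same substitution measured against the other two aryl groups gives a 1.9-fold higher number from compound 2 to compound 4 (0.27 log units; within the scatter) and a 1.1-fold lower number from compound 1 to compound 4 (0.05 log units; within the scatter), so the two extra methoxy groups and their two extra hydrogen-bond acceptors produce no step beyond the scatter from any of the three earlier compounds, and the only step beyond it at this position remains the one between the chloro and unsubstituted phenyl compounds. No measurement on hand bears on why this position responds so little to the change.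

From the compounds shown here alone, all four compounds carry an uncharged six-membered aromatic ring of carbon at this position, so it remains open whether an amine or a carboxylic acid on that ring, or a longer chain in place of it, would move the number beyond the scatter. Also open, going by these compounds, is whether a single added methoxy group on the 4-methoxyphenyl ring would read like compound 3 or like compound 4.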